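Swapping a phenyl for a pyrrolidinyl ether on the benzyl arm

A few compounds are considered here, and "the series" means these few. Any claim that something is new, unique, unknown or untested is made for them only; others in the source may bear on it.

Compound 1 `Nc1cc(Cc2ccn(Cc3cccc(-c4ccccc4)c3)n2)c2nn[nH]c2n1` and compound 2 `Nc1cc(Cc2ccn(-c3ccccn3)n2)c2nn[nH]c2n1` share one core and were tested in an assay on cells for inhibition of thyroid peroxidase (Homo sapiens), with stated times of 10 min and 15 min; on this read-out higher numbers stand for weaker inhibition and lower numbers for stronger inhibition. In this assay compound 1 gives 1100 nM, and compound 2 gives 2000 nM; the two numbers lie within the scatter of each other, so neither can be called the stronger inhibitor. Compound 3 `Nc1cc(Cc2ccn(Cc3cccc(O[C@H]4CCNC4)c3)n2)c2nn[nH]c2n1` has not yet been measured. It differs from compound 1 in a single place: (pyrrolidin-3-yl)oxy in place of phenyl on an aromatic carbon. Going by the values given here, no pair of measured compounds shows the effect of such a change, so there is no measured step to lean on, only the observation that the two known values sit close together. The expected step from compound 1 to compound 3 is a 1.4-fold lower number from compound 1 to compound 3 (0.14 log units; within the scatter), a small shift towards stronger inhibition that may well stay inside the scatter. Compound 3 is therefore estimated at 800 nM, with a plausible range from 250 nM to 2500 nM.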

Compound 3, half-maximal inhibitory concentration: 14000 nM
Compound 3: middle estimate off by 18-fold (1.24 log units), on the low side; the whole stated range lies below it.
By their numbers in this assay, from the lowest: compounds 1 and 2 (each within the scatter of the next); then compound 3.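

In this assay the exchange of phenyl for (pyrrolidin-3-yl)oxy gives a 13-fold higher number from compound 1 to compound 3 (1.10 log units; beyond the scatter) and so moves clearly towards weaker inhibition, a large step beyond the scatter. This shows that the group on this aromatic carbon does affect the read-out, even though the group that leaves and the group that enters each hold 6 heavy atoms. No available measurement explains the step.

The change replaces an aromatic ring of carbon only with a non-aromatic ring joined through oxygen and holding a nitrogen, so this one pair cannot tell which of these differences matters. A cyclopentyloxy group, which has no ring nitrogen, or a pyridyl ring, which stays aromatic and carries a nitrogen, would help to separate them.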